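The compounds below may be only part of what the source reports. "The series", "measured", "known", "first", "only" and "open" are said of these compounds alone.

This account follows the step from compound 3 to compound 4 in an ADME assay on Akata cells (Homo sapiens) for cytotoxicity, with a stated time of 7 days; on this read-out lower numbers stand for higher toxicity in this test and higher numbers for lower toxicity in this test. Compound 1 `Nc1nc(OCC(F)(F)F)c2ncn(/C=C3/CC3(CO)CO)c2n1` carries a 2,2,2-trifluoroethoxy group on the shared core. In this assay compound 1 gives > 20000 nM, which is a limit of the assay rather than a number. Compound 2 `C=CCOc1nc(N)nc2c1ncn2/C=C1/CC1(CO)CO` has an allyloxy group in its place. In this assay compound 2 gives > 20000 nM, again only a limit. Compound 3 `Nc1nc(NC2CCCC2)c2ncn(/C=C3/CC3(CO)CO)c2n1` bears a cyclopentylamino group on an aromatic carbon. In this assay compound 3 gives > 20000 nM, also a limit. Compound 3 thus stands together with the other two at the limit of > 20000 nM in this assay, at which 3 of the 3 values shown sit, and no order among the three can be read. The measured steps a step that the two limits leave unreadable from compound 1 to compound 2, a step that the two limits leave unreadable from compound 1 to compound 3 and a step that the two limits leave unreadable from compound 2 to compound 3 are accordingly all of unreadable size. Compound 4 `Nc1nc(SC2CCCC2)c2ncn(/C=C3/CC3(CO)CO)c2n1` differs from compound 3 by cyclopentylsulfanyl in place of cyclopentylamino on an aromatic carbon. Among the compounds with values here, none of the measured steps involves the cyclopentylsulfanyl group, yet every value obtained so far sits at the same limit. Compound 4 is therefore expected to show a step that the limit leaves unreadable from compound 3 to compound 4, that is, none beyond the scatter. The estimate for compound 4 in this assay is 25000 nM, with a range from 12000 nM to 60000 nM.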

Compound 4, half-maximal cytotoxic concentration: > 20000 nM
Compound 4 gave a limit, no number (the forecaster's own chance of this, stated with the estimate: 80%); the middle value is on the limit's open side.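

Within the data shown here, compound 4, like compounds 1, 2 and 3, gives only a limit in this assay, so no step from any of them to compound 4 can be read: the limit of > 20000 nM in this assay, at which 4 of the 4 values shown sit. The compounds shown leave open whether cyclopentylsulfanyl, cyclopentylamino, allyloxy and 2,2,2-trifluoroethoxy differ at all on the shared core in this assay.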